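Changing the hydroxy side chain of compound 3

This account rests on a few compounds, and the source may have more. Where it says the series, first, only, none or still open, it means among the compounds named here.

Measured in an ADME assay on HepG2 cells (Homo sapiens) for cytotoxicity, read by MTT assay, with a stated time of 72 h; a lower number here means that less compound is tolerated, a higher number that more compound is tolerated:
Compound 1 `CC(O)(C#Cc1cc(Cl)cn2c([N+](=O)[O-])c(CS(=O)(=O)c3ccccc3)nc12)c1ccccc1` gives 18800 nM
Compound 2 `O=[N+]([O-])c1c(CS(=O)(=O)c2ccccc2)nc2c(C#CCO)cc(Cl)cn12` gives 10100 nM
Compound 3 `CC(C)(O)C#Cc1cc(Cl)cn2c([N+](=O)[O-])c(CS(=O)(=O)c3ccccc3)nc12` gives > 62500 nM, which is a limit of the assay and not a number

Compound 3 stands at the limit of > 62500 nM in this assay, at which 1 of the 3 values shown sits, so its exact place on the scale is not known. Compound 4 `CCC(O)CC#Cc1cc(Cl)cn2c([N+](=O)[O-])c(CS(=O)(=O)c3ccccc3)nc12` differs from compound 3 in one place: 2-hydroxybutyl in place of 1-hydroxy-1-methylethyl on a triple-bonded carbon. In words, 2-hydroxybutyl replaces 1-hydroxy-1-methylethyl on a triple-bonded carbon.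

Among the measured compounds shown here, no measured step makes this exact exchange. The nearest evidence is the pair of steps ending at compound 3, namely an at least 3.3-fold higher number from compound 1 to compound 3 (0.52 log units; beyond the scatter) and an at least 6.1-fold higher number from compound 2 to compound 3 (0.79 log units; beyond the scatter). Both lie beyond the scatter, and both are open-ended. The remaining step, a 1.9-fold lower number from compound 1 to compound 2 (0.27 log units; within the scatter), lies within the scatter, so the side chains of compounds 1 and 2 give values that cannot be told apart.

Only the side chain of compound 3 reaches the limit among these three. Losing it is therefore expected to move the number back towards compounds 1 and 2, a lower number by a modest margin, although a result at the limit remains possible. The expected step is an at least 2.5-fold lower number from compound 3 to compound 4 (0.39 log units; beyond the scatter). For compound 4 the estimated value is 25000 nM, with an expected range from 10000 nM to 60000 nM.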

Compound 4, half-maximal cytotoxic concentration: > 62500 nM
Compound 4 ended at the assay's limit; the forecaster's own chance of this, stated with the estimate: 25%; middle value at least 2.5-fold (0.39 log units) away from the limit.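

In this assay, compound 4 joins compound 3 at a limit of the assay and not at a number: the limit of > 62500 nM in this assay, at which 2 of the 4 values shown sit. The result shows that reaching this limit does not belong to the 1-hydroxy-1-methylethyl group alone, since 2-hydroxybutyl on the same triple-bonded carbon reaches it too, even with its larger count of heavy atoms. Measured against the two side chains that stay on the scale, the new chain gives an at least 6.1-fold higher number from compound 2 to compound 4 (0.79 log units; beyond the scatter) and an at least 3.3-fold higher number from compound 1 to compound 4 (0.52 log units; beyond the scatter), so that 2-hydroxybutyl groups with 1-hydroxy-1-methylethyl and apart from both hydroxymethyl and 1-hydroxy-1-phenylethyl, while the step between the two compounds at the limit cannot be read.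

As far as these compounds go, how far compound 3 and compound 4 each lie past the limit stays unknown, so the two chains cannot be ranked against each other, and the four compounds do not say which feature of the side chain separates the two at the limit from the two on the scale. Also open, from the compounds shown here alone, is whether the number stays at the limit with an amine or a carboxylic acid in place of the hydroxy group, or with a longer chain.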